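The source may hold more compounds than are shown below. What is called first, only, known or untested is meant among the compounds shown, and "the series" means these compounds.

Measured compounds in a physicochemical assay for lipophilicity, in phosphate buffer, measured as octanol-water partition; on this read-out higher numbers stand for higher lipophilicity and lower numbers for lower lipophilicity:

compound 1 `Cc1ccc(Oc2ccc(/C=N/n3c(C)nc4ccccc4c3=O)cc2)cc1` gives 4.32
compound 2 `Cc1nc2ccccc2c(=O)n1/N=C/c1ccc(Oc2ccc3ccccc3c2)cc1` gives 5.22
compound 3 `Cc1ccc(Oc2ccc(/C=N/n3c(-c4ccccc4)nc4ccccc4c3=O)cc2)cc1` gives 6.29

Compound 3 stands highest of the three numbers; compound 2 sits nearer to it and compound 1 furthest. The two steps seen so far both raised the read-out: a number 0.90 log units higher from compound 1 to compound 2 (beyond the scatter) and a number 1.97 log units higher from compound 1 to compound 3 (beyond the scatter). Compound 4 `Cc1cc(Oc2ccc(/C=N/n3c(-c4ccccc4)nc4ccccc4c3=O)cc2)ccc1Cl` differs from compound 3 by 4-chloro-3-methylphenyl in place of 4-methylphenyl on an oxygen on an aromatic ring. Neither step seen so far changes a ring in this way, so they bear only loosely, yet each time atoms were added to the same part of the shared core the number rose. A modest rise in this assay is therefore expected, smaller than either step seen, as a step of a number 0.61 log units higher from compound 3 to compound 4 (beyond the scatter). Compound 4 is estimated at 6.9, within 6.5 to 7.4.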

Compound 4, partition coefficient: 6.52
Compound 4: the middle estimate sits 0.38 log units above what was measured; the range from low to high includes it.
By their numbers in this assay, from the lowest: compound 1; then compound 2; then compounds 3 and 4 (each within the scatter of the next).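

In this assay, 4-chloro-3-methylphenyl in place of 4-methylphenyl on an oxygen on an aromatic ring gives a number 0.23 log units higher from compound 3 to compound 4 (within the scatter), so this change cannot be told apart from repeat measurement. At this same place, the step of a number 0.90 log units higher from compound 1 to compound 2 (beyond the scatter) shows that a change here can exceed the scatter, so not every change at this place does so. No measurement shown accounts for either outcome.

From the compounds shown here alone, how an amine or a carboxylic acid on this ring would read in this assay stays open. Going by these compounds, whether the step of a number 0.23 log units higher from compound 3 to compound 4 (within the scatter) would hold on the core of compound 1 also stays open.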